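The source may report more compounds than this note shows. Statements on the series, on what has been measured and on what is new or still open speak of the compounds shown alone.

Compound 1 `O=C(c1ccc2c(c1)OCCO2)C1CCN(Cc2coc(-c3ccc(C(F)(F)F)cc3)n2)CC1`: > 150 ug/mL in an ADME assay on HEK293 cells (Homo sapiens) for cytotoxicity, read by MTT assay, with a stated time of 36 h (a higher number here means a weaker inhibitor, a lower number a stronger inhibitor), a limit of the assay.
Compound 2 `O=C(c1ccc2c(c1)OCCO2)C1CCN(Cc2coc(-c3ccc(F)c(F)c3)n2)CC1`: > 150 ug/mL in this assay, likewise a limit.

Compound 2 stands at the limit of the assay, as does compound 1; both sit at the limit of > 150 ug/mL in this assay, at which 2 of the 2 values shown sit. The step that the two limits leave unreadable from compound 1 to compound 2 is therefore unreadable in size and direction. Compound 3 `O=C(c1ccc2c(c1)OCCO2)C1CCN(Cc2coc(-c3ccco3)n2)CC1` differs from compound 2 by furan-2-yl in place of 3,4-difluorophenyl on an aromatic carbon. No measured step bears readably on this change, so the expected step that the limit leaves unreadable from compound 2 to compound 3 rests on no readable measured step; the shared core of compound 2 has not yet shown a value inside the range of this assay. Compound 3 is expected to give 160 ug/mL, between 60 ug/mL and 400 ug/mL, most likely again a limit.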

Compound 3, half-maximal inhibitory concentration: > 150 ug/mL
Compound 3: no number, only a limit; the forecaster's own chance of this, stated with the estimate: 75%; the middle value is on the limit's open side.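

Going by these compounds alone, compound 3, like compound 1 and compound 2, gives only a limit, so no step among the three can be read: the limit of > 150 ug/mL in this assay, at which 3 of the 3 values shown sit. The compounds shown leave open whether any change on the shared core gives a value inside the range of this assay.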